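Lengthening the chain from compound 2 to compound 3

The source may report more compounds than this note shows. Statements on the series, on what has been measured and on what is new or still open speak of the compounds shown alone.

Measured so far in a functional assay on HepG2 cells (Homo sapiens) for inhibition, read by MTT assay, with a stated time of 72 h (a lower number here means a stronger inhibitor, a higher number a weaker inhibitor), for the series:
- compound 1 `CCc1ccc(NC(=O)C2CCN(C/C=C/c3ccccc3)CC2)cc1` gives 23300 nM
- compound 2 `CCCCc1ccc(NC(=O)C2CCN(C/C=C/c3ccccc3)CC2)cc1` gives 4320 nM

Compound 2 at 4320 nM holds the lower of the two numbers. Next is compound 3 `CCCCCc1ccc(NC(=O)C2CCN(C/C=C/c3ccccc3)CC2)cc1` with the change methyl in place of hydrogen on a saturated chain carbon, four bonds along the chain from an aromatic carbon on the same chain, the rest of the core staying as it is. Among the measured compounds shown here, only one measured step bears on this: a 5.4-fold lower number from compound 1 to compound 2 (0.73 log units; beyond the scatter) came with ethyl in place of hydrogen on the chain. One step does not make a trend, and nothing yet shows whether the direction holds further out. A smaller step in the same direction is expected in this assay for methyl, possibly no larger than the scatter. For compound 3 the estimate is 2800 nM with an expected range of 1100 nM to 7000 nM for the measurement. This estimate means an expected 1.5-fold lower number from compound 2 to compound 3 (0.19 log units; within the scatter) on the numbers.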

Compound 3, half-maximal inhibitory concentration: 2890 nM
Estimate against measurement, compound 3: 1.0-fold (0.01 log units) below; the measured number falls inside the stated range.
By their numbers in this assay, from the lowest: compounds 3 and 2 (each within the scatter of the next); then compound 1.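

In this assay, the methyl added on the saturated chain carbon, four bonds along the chain from an aromatic carbon, gives a 1.5-fold lower number from compound 2 to compound 3 (0.17 log units; within the scatter), so at this chain length the extension does not separate compound 3 from compound 2. The separation from compound 1 stands, with propyl in place of hydrogen on the saturated chain carbon two bonds along the chain from an aromatic carbon giving an 8.1-fold lower number from compound 1 to compound 3 (0.91 log units; beyond the scatter), and the series now shows that this distance is not widened beyond the scatter by the last added carbon. No measured information accounts for either step.

A longer chain such as hexyl could show whether the numbers stay level or move again. A terminal amine or carboxylic acid on the same chain remains an open test of how far the position tolerates a group other than plain alkyl.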